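Amide nitrogen substituent and channel agonism in the series

The source may hold more compounds than are shown below. What is called first, only, known or untested is meant among the compounds shown, and "the series" means these compounds.

Notes. The shared core of this set carries an amide nitrogen that bears one varied group. Compound 1 `Cc1ccc(OCC(=O)N(Cc2cccs2)c2ccn(C)n2)cc1` carries 1-methyl-1H-pyrazol-3-yl there, and in an assay on HEK293 cells for agonist activity at transient receptor potential cation channel subfamily M member 8 (Homo sapiens), read by fluorescence and calcium flux, with a stated time of 15 min (on this read-out higher numbers stand for an effect only at larger amounts of compound and lower numbers for an effect already at smaller amounts), compound 1 gives 855 nM. Compound 2 `Cc1ccc(OCC(=O)N(Cc2cccs2)C(C)(C)C)cc1` carries tert-butyl and gives 11000 nM. Compound 3 `Cc1ccc(OCC(=O)N(C)Cc2cccs2)cc1` carries methyl and gives 400 nM, the lowest of the three numbers, with a 2.1-fold lower number from compound 1 to compound 3 (0.33 log units; beyond the scatter) and a 28-fold lower number from compound 2 to compound 3 (1.44 log units; beyond the scatter).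

The next compound, compound 4 `Cc1ccc(OCC(=O)N(Cc2cccs2)c2cn[nH]c2)cc1`, differs from compound 3 by 1H-pyrazol-4-yl in place of methyl on an amide-type nitrogen. The step that bears on this is the comparison of methyl with 1-methyl-1H-pyrazol-3-yl on the same nitrogen, a 2.1-fold lower number from compound 1 to compound 3 (0.33 log units; beyond the scatter), a modest step; the comparison with tert-butyl, a 28-fold lower number from compound 2 to compound 3 (1.44 log units; beyond the scatter), is large but concerns a saturated branched group rather than a ring. Going by the values given here, no measured compound carries 1H-pyrazol-4-yl, so the hydrogen-bond donor it brings has no precedent in this set. The expectation is therefore a modest rise in number, around a 2.3-fold higher number from compound 3 to compound 4 (0.35 log units; beyond the scatter), in this assay. Compound 4 is estimated at 900 nM, with an expected range of 300 nM to 3000 nM.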

Compound 4, half-maximal effective concentration: 1.4 nM
For compound 4 the middle estimate is 640-fold (2.81 log units) above the measured one; the whole stated range lies above it.
By their numbers in this assay, from the lowest: compound 4; then compound 3; then compound 1; then compound 2.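

In this assay, the amide-type nitrogen proves far more sensitive than the first three compounds suggested, and its best group so far is not the smallest: 1H-pyrazol-4-yl in place of methyl gives a 290-fold lower number from compound 3 to compound 4 (2.46 log units; beyond the scatter), although methyl had stood lowest of the earlier groups. A ring at this position does not by itself bring the low number, as 1H-pyrazol-4-yl in place of 1-methyl-1H-pyrazol-3-yl gives a 610-fold lower number from compound 1 to compound 4 (2.79 log units; beyond the scatter), and compound 1 still stands above compound 3; the two rings differ in more than one feature, so this step cannot be assigned to any single one. With 1H-pyrazol-4-yl in place of tert-butyl giving a 7900-fold lower number from compound 2 to compound 4 (3.90 log units; beyond the scatter), changes at this one nitrogen now span a very wide range of numbers, and that range follows no simple order of group size among the four compounds.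

Nothing available here explains the size of these steps. The compounds shown leave open whether the ring hydrogen-bond donor or the ring attachment carries the effect, a question that 1-methyl-1H-pyrazol-4-yl, 1H-pyrazol-3-yl or a phenyl ring on the same nitrogen would help to separate.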